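The compounds below may be only part of what the source reports. "The series", "measured", "known", "first", "only" and "open" are said of these compounds alone.

Measured compounds in a functional assay on HT-29 cells (Homo sapiens) for antiproliferative activity, read by sulforhodamine B assay, with a stated time of 48 h; a higher number here means that more compound is tolerated, a lower number that less compound is tolerated:
- Compound 1, `COc1ccc(OC)c(/C=C/c2nnc(Nc3ccc(Cl)cc3)o2)c1`, gives 82100 nM.
- Compound 2, `COc1ccc(OC)c(/C=C/C(=O)N/N=C/c2ccc(Cl)cc2)c1`, gives only a limit, > 100000 nM.

Compound 2 thus stands at the limit of this assay rather than at a number; the value sits at the limit of > 100000 nM in this assay, at which 1 of the 2 values shown sits, and only the value of compound 1 is a measured figure. Whether compound 2 is tolerated beyond that limit cannot be read from the data.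

Compound 3, `COc1ccc(OC)c(/C=C/C(=O)N/N=C/c2ccccc2)c1`, has not been measured in this assay. It differs from compound 2 by hydrogen in place of chloro on an aromatic carbon, which in words is hydrogen in place of chloro on an aromatic carbon. Going by the values given here, no measured pair shows a step of this kind, so the size of the step is open. Since compound 2 already sits at the limit, the step is expected to be none beyond the scatter, a step that the limit leaves unreadable from compound 2 to compound 3, and compound 3 is expected at 150000 nM, within 60000 nM to 400000 nM.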

Compound 3, concentration lethal to 50% of the cells: > 100000 nM
Compound 3 ended at the assay's limit; the forecaster's own chance of this, stated with the estimate: 75%; the middle value does not contradict the limit.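

Compound 2 and compound 3 both rest on a limit rather than a number, so no step can be read between them: the limit of > 100000 nM in this assay, at which 2 of the 3 values shown sit. In this assay the compounds shown leave open what the change from 4-chlorophenyl to phenyl does.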